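Lengthening the Ethyl Chain on Compound 3 to Butyl

A few compounds are considered here, and "the series" means these few. Any claim that something is new, unique, unknown or untested is made for them only; others in the source may bear on it.

Compound 1, `COc1cc(-c2noc(-c3ccccc3)n2)cc(OC)c1OC`: > 50000 nM
Compound 2, `COc1cc(-c2noc(-c3ccc(N)cc3)n2)cc(OC)c1OC`: 1700 nM
Compound 3, `CCc1ccc(-c2nc(-c3cc(OC)c(OC)c(OC)c3)no2)cc1`: > 50000 nM

In a functional assay on cells (Splenocyte, Mus musculus, strain BALB/c) for inhibition, read by scintillation counting and thymidine incorporation, with stated times of 48 h and 8 h (on this read-out higher numbers stand for weaker inhibition and lower numbers for stronger inhibition), compound 1 reaches only a limit of the assay, > 50000 nM. Compound 2 gives a number, 1700 nM. Compound 3 again reaches only a limit, > 50000 nM. Compound 3 therefore stands at the limit of > 50000 nM in this assay, at which 2 of the 3 values shown sit, together with compound 1, and is separated from compound 2 by an at least 29-fold higher number from compound 2 to compound 3 (1.46 log units; beyond the scatter). The step that the two limits leave unreadable from compound 1 to compound 3 cannot be sized, and the step of an at least 29-fold lower number from compound 1 to compound 2 (1.46 log units; beyond the scatter) shows how far a different replacement on the same aromatic carbon reached.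

Compound 4, `CCCCc1ccc(-c2nc(-c3cc(OC)c(OC)c(OC)c3)no2)cc1`, carries one more change: ethyl in place of hydrogen on a saturated chain carbon, two bonds along the chain from an aromatic carbon. Among the compounds with values here, the only measured steps that touch the ethyl group are those to compound 3, and both end at a limit, so none of them gives a readable size for growing this chain further. With compound 3 already at the limit, the step from compound 3 to compound 4 is expected to be none beyond the scatter, a number no higher from compound 3 to compound 4 (the limit leaves the size open), and compound 4 is expected most probably to return a limit as well. The estimate for compound 4 is 50000 nM, with a range from 15000 nM to 150000 nM.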

Compound 4, half-maximal inhibitory concentration: 36200 nM
Compound 4: middle estimate off by 1.4-fold (0.14 log units), on the high side; the range from low to high includes it.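

Lengthening the ethyl chain to butyl gives a real number: in this assay compound 4 gives 36200 nM, so a chain on this aromatic carbon can now be placed on the scale, which neither the hydrogen of compound 1 nor the ethyl of compound 3 allowed. Yet the comparison with those two compounds yields only floors, an at least 1.3-fold lower number from compound 3 to compound 4 (0.14 log units; that floor lies within the scatter) and an at least 1.3-fold lower number from compound 1 to compound 4 (0.14 log units; that floor lies within the scatter), so neither step can be called a gain beyond the scatter. Butyl also remains far behind the amino group, with a 21-fold higher number from compound 2 to compound 4 (1.33 log units; beyond the scatter), and compound 2 stays the strongest of the four.

How much the chain itself contributes stays unsettled, since the hydrogen and ethyl compounds offer no number to compare with compound 4: the limit of > 50000 nM in this assay, at which 2 of the 4 values shown sit.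

Also open, as far as these compounds go, is whether a longer chain such as hexyl would bring the number down further, and whether a dimethylamino group on the same aromatic carbon would come closer to the amino group of compound 2.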